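Fluoro on the benzyl group of compound 3

A few compounds are considered here, and "the series" means these few. Any claim that something is new, unique, unknown or untested is made for them only; others in the source may bear on it.

Measured in a functional assay on RS4-11 cells (Homo sapiens) for inhibition, read by CCK-8 assay, with a stated time of 48 h, tested at 20 uM; on this read-out lower numbers stand for less inhibition of growth and higher numbers for more inhibition of growth at the one concentration tested:
- compound 1 `COc1ccc(S(=O)(=O)Oc2ccccc2/C=C(\C#N)C(=O)Nc2nnc(Cc3ccccc3)s2)cc1`: 78%
- compound 2 `N#C/C(=C\c1ccccc1OS(=O)(=O)c1ccccc1[N+](=O)[O-])C(=O)Nc1nnc(Cc2ccccc2)s1`: 71%
- compound 3 `N#C/C(=C\c1ccccc1OS(=O)(=O)c1ccc(Cl)cc1)C(=O)Nc1nnc(Cc2ccccc2)s1`: 73%

Compound 3 is not separated from the other two measured compounds: a number 5 percentage points lower from compound 1 to compound 3 (within the scatter), and a number 2 percentage points higher from compound 2 to compound 3 (within the scatter). The next compound, compound 4 `N#C/C(=C\c1ccccc1OS(=O)(=O)c1ccc(Cl)cc1)C(=O)Nc1nnc(Cc2ccc(F)cc2)s1`, keeps the 4-chlorophenyl on the sulfonyl sulfur and turns benzyl to 4-fluorobenzyl, with fluoro in place of hydrogen on an aromatic carbon.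

Among the measured compounds shown here, no measured step touches the benzyl group. All three fall on the aromatic group at the sulfonyl sulfur; the third is a number 7 percentage points lower from compound 1 to compound 2 (within the scatter). They bear on the new change only indirectly, showing that exchanges elsewhere in these compounds stayed within the scatter. For the measured compounds named here, the data hold no example of a substituent on the benzyl group, so they give no direction. No step beyond the scatter is therefore expected in this assay.

The estimate starts from compound 3 at 73%. The expected change is no change at the digits printed from compound 3 to compound 4 (within the scatter). For compound 4 the estimated value is 73%, with an expected range of 60% to 85%.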

Compound 4, percent growth inhibition at one concentration: 68%
Estimate against measurement, compound 4: 5 percentage points above, and the stated range covers the measured number.
By their numbers in this assay, from the lowest: compounds 4, 2, 3 and 1 (each within the scatter of the next).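

In this assay, the exchange of hydrogen for fluoro, which turns benzyl into 4-fluorobenzyl while the 4-chlorophenyl stays on the sulfonyl sulfur, gives a number 5 percentage points lower from compound 3 to compound 4 (within the scatter), so the step does not separate the two compounds. Among the compounds shown here, this is the first reading at the benzyl group rather than at the aromatic group on the sulfonyl sulfur, and it shows that this position carries a fluoro, para to a large group, without a step beyond the scatter; one substituent, however, sets no direction for the position. No measurement is available that bears on the step or could account for it.

Open, from the compounds shown here alone, is whether a larger or differently built group on the same aromatic ring, such as an amine, a carboxylic acid, a methoxy group or a longer alkyl chain, would give a step beyond the scatter at this position. Also open, going by these compounds, is whether the hydrogen-to-fluoro exchange reads the same with 4-methoxyphenyl or 2-nitrophenyl on the sulfonyl sulfur, since the step is available only with 4-chlorophenyl there.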